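The source may report more compounds than this note shows. Statements on the series, on what has been measured and on what is new or still open speak of the compounds shown alone.

Of the compounds shown here, three of one series have been measured in a functional assay on HepG2 cells for inhibition of squalene monooxygenase (Homo sapiens); a higher number here means a weaker inhibitor, a lower number a stronger inhibitor. Compound 1 `CCN(C/C=C/C#CC(C)(C)C)Cc1cccc(OCCN(C)S(=O)(=O)c2cccs2)c1` gives 60 nM. Compound 2 `CCN(C/C=C/C#CC(C)(C)C)Cc1cccc(OCCN(C)S(=O)(=O)c2ccsc2)c1` gives 250 nM, and compound 3 `CCN(C/C=C/C#CC(C)(C)C)Cc1cccc(OCCN(C)S(=O)(=O)Cc2cccs2)c1` gives 200 nM. Compound 3 thus stands second highest of the three numbers: its nearest neighbour is compound 2, and the step of a 1.3-fold lower number from compound 2 to compound 3 (0.10 log units; within the scatter) lies within the scatter, while the step of a 3.3-fold higher number from compound 1 to compound 3 (0.52 log units; beyond the scatter) lies beyond it. The remaining step, a 4.2-fold higher number from compound 1 to compound 2 (0.62 log units; beyond the scatter), is of similar modest size. Compound 4 `CCN(C/C=C/C#CC(C)(C)C)Cc1cccc(OCCCS(=O)(=O)c2cccs2)c1` differs from compound 3 by a group of 9 heavy atoms (5 carbon, 2 oxygen, 2 sulfur; one five-membered aromatic ring with 1 hetero atom) in place of a group of 11 heavy atoms (6 carbon, 1 nitrogen, 2 oxygen, 2 sulfur; one five-membered aromatic ring with 1 hetero atom), on a saturated chain carbon, two bonds along the chain from an oxygen on an aromatic ring. Among the compounds with values here, none of the measured steps alters this part of the molecule; all of them concern the group on the sulfonyl sulfur. Compound 4 does carry thiophen-2-yl directly on the sulfonyl sulfur, as compound 1 does, and compound 1 gave the lowest number. Within the data shown here, the change in the chain itself has no precedent among the measured compounds. Compound 4 is therefore expected to give 90 nM, in the range 30 nM to 300 nM. The step of a 2.2-fold lower number from compound 3 to compound 4 (0.35 log units; beyond the scatter) is estimated as a modest lowering, with wide uncertainty.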

Compound 4, half-maximal inhibitory concentration: 290 nM
Compound 4: middle estimate off by 3.2-fold (0.51 log units), on the low side; measured number inside the range.
By their numbers in this assay, from the lowest: compound 1; then compounds 3, 2 and 4 (each within the scatter of the next).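

In this assay, within the data shown here, this is the first measured change on a saturated chain carbon, two bonds along the chain from an oxygen on an aromatic ring, and it matters. With thiophen-2-yl kept on the sulfonyl sulfur, the group of 9 heavy atoms, which holds no nitrogen, in place of the group of 10 heavy atoms gives a 4.8-fold higher number from compound 1 to compound 4 (0.68 log units; beyond the scatter) and so thiophen-2-yl alone does not secure the low number of compound 1, whereas a 1.5-fold higher number from compound 3 to compound 4 (0.16 log units; within the scatter) and a 1.2-fold higher number from compound 2 to compound 4 (0.06 log units; within the scatter) both stay within the scatter. Nothing further is available to account for these steps.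

The compounds shown leave open whether the nitrogen of compound 1 itself or the methyl on it accounts for the step, which a hydrogen in place of that methyl would address. Also open, as far as these compounds go, is how a longer chain, or a phenyl on the sulfonyl sulfur, would read in this assay on this series.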